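Metabolic Stability at the Limit: From Compound 2 to Compound 4

The source may report more compounds than this note shows. Statements on the series, on what has been measured and on what is new or still open speak of the compounds shown alone.

Of the compounds shown here, three of a shared core have been tested in an in vitro ADME assay on microsomes from liver (Homo sapiens) for metabolic stability; a lower number here means that the compound disappears faster, a higher number that the compound lasts longer. Compound 1 `CS(=O)(=O)Nc1ccc2c(c1)S(=O)(=O)N=C(C1=C(O)C3CCCC3N(Cc3ccc(F)cn3)C1=O)N2` reaches only a limit of the assay, > 1 h. Compound 3 `CS(=O)(=O)Nc1ccc2c(c1)S(=O)(=O)N=C(C1=C(O)[C@@H]3CCCC[C@@H]3N(Cc3ccc(F)cc3)C1=O)N2` likewise ends at a limit, > 1 h. Compound 2 `Cc1cc(CN2C(=O)C(C3=NS(=O)(=O)c4cc(NS(C)(=O)=O)ccc4N3)=C(O)[C@H]3CCC[C@H]32)ccc1F` also sits at a limit in this assay, > 1 h. Compound 2 therefore stands on (the limit of > 1 h in this assay, at which 3 of the 3 values shown sit), and no number separates it from compound 1 or compound 3.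

Compound 4 `CS(=O)(=O)Nc1ccc2c(c1)S(=O)(=O)N=C(C1=C(O)[C@H]3CCC[C@H]3N(Cc3cccc(C(F)(F)F)c3)C1=O)N2` has not yet been measured in this assay. It differs from compound 2 by 3-(trifluoromethyl)phenyl in place of 4-fluoro-3-methylphenyl on a saturated chain carbon bound to an amide-type nitrogen in a ring. Among the measured compounds shown here, no step between two measured compounds is available, so the size and direction of such a change cannot be read from these data. The step that the limit leaves unreadable from compound 2 to compound 4 is expected to be none beyond the scatter, because compound 2 already rests on (the limit of > 1 h in this assay, at which 3 of the 3 values shown sit). Compound 4 is estimated at 1.5 h, within a range from 0.5 h to 4 h, and most likely this assay will again report only a limit.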

Compound 4, half-life: > 1 h
Compound 4 ended at the assay's limit; the forecaster's own chance of this, stated with the estimate: 75%; the middle value does not contradict the limit.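

No step can be read from compound 2 to compound 4, because both end at the same limit: the limit of > 1 h in this assay, at which 4 of the 4 values shown sit.

The compounds shown leave open how long any of them actually lasts in this assay, and whether 3-(trifluoromethyl)phenyl in place of 4-fluoro-3-methylphenyl changes that at all.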